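Swapping a fluorinated ring for a hydroxylated one in a permeability assay

The source may hold more compounds than are shown below. What is called first, only, known or untested is meant among the compounds shown, and "the series" means these compounds.

Measured so far:
compound 1 `COc1cccc(CNCCCNc2ccnc3cc(Cc4ccccc4)ccc23)c1O` 23 10^-6 cm/s
compound 2 `CCC(CC)c1ccc2c(NCCCNCc3cccc(OC)c3O)ccnc2c1` 23 10^-6 cm/s
compound 3 `COc1ccc(F)cc1CNCCCNc1ccnc2cc(Cc3ccc(F)cc3Cl)ccc12` 23 10^-6 cm/s

In an ADME assay for permeability, using PAMPA, with a stated time of 30 min, at pH 7.4 (a lower number here means that the compound crosses the layer more slowly, a higher number that the compound crosses the layer faster), compound 3 gives 23 10^-6 cm/s, level with compound 1 and compound 2 within the scatter. Among the compounds with values here, the one step recorded, no change at the digits printed from compound 1 to compound 2 (within the scatter), changed a group elsewhere on the shared core and left the read-out unchanged.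

Compound 4 `COc1cccc(CNCCCNc2ccnc3cc(Cc4ccc(F)cc4Cl)ccc23)c1O` differs from compound 3 at one place:
2-hydroxy-3-methoxyphenyl in place of 5-fluoro-2-methoxyphenyl on a saturated chain carbon bound to an amine nitrogen

Within the data shown here, no measured step touches this place, so the expectation can rest only on the fact that three compounds of this family, with different groups at several positions, all sit at the same value. Among the measured compounds shown here, a new hydrogen-bond donor enters, but the data give no step to weigh it. The step from compound 3 to compound 4 is therefore expected to be about a 1.1-fold lower number from compound 3 to compound 4 (0.04 log units; within the scatter), within the scatter. Compound 4 is estimated at 21 10^-6 cm/s, with a range from 11 10^-6 cm/s to 38 10^-6 cm/s.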

Compound 4, apparent permeability: 23 10^-6 cm/s
Estimate against measurement, compound 4: 1.1-fold (0.04 log units) below; the range from low to high includes it.
By their numbers in this assay, from the lowest: compounds 1, 2, 3 and 4 (each within the scatter of the next).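

In this assay, 2-hydroxy-3-methoxyphenyl in place of 5-fluoro-2-methoxyphenyl gives no change at the digits printed from compound 3 to compound 4 (within the scatter) and is the only step shown at this place, on a saturated chain carbon bound to an amine nitrogen. The entering group has 1 hydrogen-bond donor and the leaving group has 0, yet the step stays within the scatter. With 2-chloro-4-fluorobenzyl in place of pentan-3-yl, the read-out shows no change at the digits printed from compound 2 to compound 4 (within the scatter) and with 2-chloro-4-fluorophenyl in place of phenyl it shows no change at the digits printed from compound 1 to compound 4 (within the scatter) so every step read so far in this small set stays within the scatter. No separate measurement bears on this result.

From the compounds shown here alone, the swap alters the hydroxy group, the methoxy group and the fluorine together, so their separate shares stay open. Going by these compounds, what a carboxylic acid or a morpholine at this place would do also remains open.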